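Phenoxy swap on the shared core: compound 1 to compound 4

This account rests on a few compounds, and the source may have more. Where it says the series, first, only, none or still open, it means among the compounds named here.

Of the compounds shown here, three have been measured in a functional assay on OVCAR-8 cells (Homo sapiens) for inhibition, read by sulforhodamine B assay, with a stated time of 48 h; a lower number here means a stronger inhibitor of growth, a higher number a weaker inhibitor of growth. Compound 1 `Nc1cc(N)c2nc(-c3ccccc3)c(Oc3ccc(Cl)c(Cl)c3)nc2c1` gives 28200 nM in this assay; compound 2 `COc1ccc(CNc2nc3cc(N)cc(N)c3nc2-c2ccccc2)cc1OC` gives 6760 nM; compound 3 `COc1cc(CNc2nc3cc(N)cc(N)c3nc2-c2ccccc2)cc(OC)c1OC` gives 6920 nM. Compound 1 thus stands at the weak end of the three: its number lies above that of compound 3 and that of compound 2 by margins beyond the scatter, so it is the weakest growth inhibitor measured so far. Among the measured compounds shown here, the one measured step between neighbours, a 1.0-fold higher number from compound 2 to compound 3 (0.01 log units; within the scatter), concerns a methoxy group added on an aromatic carbon elsewhere in the molecule and says nothing about the phenoxy part.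

Compound 4 `Nc1cc(N)c2nc(-c3ccccc3)c(Oc3ccc(F)cc3)nc2c1` differs from compound 1 in one place: 4-fluorophenyl in place of 3,4-dichlorophenyl on an oxygen on an aromatic ring. For the measured compounds named here, no measured pair alters the substituents on the phenoxy ring, so nothing in the set bears directly on this step, and the only step that is known sits within the scatter. The expectation for compound 4 in this assay is therefore set close to compound 1, with no step beyond the scatter in either direction and a deliberately wide range. The expected step of a 1.0-fold lower number from compound 1 to compound 4 (0.00 log units; within the scatter) is essentially flat. Compound 4 is estimated at 28000 nM, with a range from 9000 nM to 90000 nM.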

Compound 4, concentration for 50% growth inhibition: 22400 nM
Compound 4: the middle estimate sits 1.3-fold (0.10 log units) above what was measured; the measured number falls inside the stated range.
By their numbers in this assay, from the lowest: compounds 2 and 3 (each within the scatter of the next); then compounds 4 and 1 (each within the scatter of the next).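

In this assay the phenoxy ring on the shared core shows its first measured substituent change, and replacing 3,4-dichlorophenyl with 4-fluorophenyl on an oxygen on an aromatic ring gives a 1.3-fold lower number from compound 1 to compound 4 (0.10 log units; within the scatter) and thus no readable shift in growth inhibition. For this one pair, the 3,4-dichlorophenoxy and 4-fluorophenoxy groups cannot be told apart by this read-out, even though the change removes both chlorine atoms and introduces a fluorine, so neither group can be ranked above the other at this position. No supporting data are available to explain why the number stays within the scatter across this change.

A single flat step cannot show whether the phenoxy ring is generally insensitive to substitution or whether these two patterns merely happen to coincide, and the separate contributions of each chlorine and of the fluorine remain unresolved. An unsubstituted phenoxy group, a phenoxy ring bearing a carboxylic acid or a dimethylamino group, and a benzylamine in place of the phenoxy group on the core of compound 1 would all test this position further.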